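The source may hold more compounds than are shown below. What is called first, only, known or untested is meant among the compounds shown, and "the series" means these compounds.

Among the compounds with values here, compound 2 `COc1ncc(-n2cnc3cnc(-c4ccc(F)cc4C)cc32)cn1` gives 2900 nM in a functional assay on HL-60 cells (Homo sapiens) for activation, read by flow cytometry, with a stated time of 4 days (a higher number here means that more compound is needed for the effect, a lower number that less compound is needed), the highest of the two numbers so far, against compound 1 `COc1ccc(-n2cnc3cnc(-c4ccc(F)cc4C)cc32)cc1` with 6 nM. Within the data shown here, the single measured step at this position, a 480-fold higher number from compound 1 to compound 2 (2.68 log units; beyond the scatter), was large, so the group on the aromatic nitrogen matters. Among the measured compounds shown here, compound 3 `Cc1cc(F)ccc1-c1cc2c(cn1)ncn2CC1CC1` differs from compound 2 by cyclopropylmethyl in place of 2-methoxypyrimidin-5-yl on an aromatic nitrogen; no measured step covers an aryl-to-alkyl exchange here, so the direction is open. Given the large 480-fold higher number from compound 1 to compound 2 (2.68 log units; beyond the scatter), a step of some size is expected, guessed downward: a 5.8-fold lower number from compound 2 to compound 3 (0.76 log units; beyond the scatter). Compound 3 is estimated at 500 nM, range 30 nM to 8000 nM.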

Compound 3, half-maximal effective concentration: > 30000 nM
Compound 3 was reported as a limit; the forecaster's own chance of this, stated with the estimate: 5%; middle value at least 60-fold (1.77 log units) from the limit.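

The value for compound 3 is a limit of the assay, not a number: the limit of > 30000 nM in this assay, at which 1 of the 3 values shown sits. Exchanging the aromatic group on the ring nitrogen for cyclopropylmethyl gives an at least 10-fold higher number from compound 2 to compound 3 (1.01 log units; beyond the scatter), and against the better aryl group gives an at least 5000-fold higher number from compound 1 to compound 3 (3.69 log units; beyond the scatter). Within the data shown here, both aryl compounds give a measured value in this assay, including compound 2, whereas the one alkyl compound gives only a limit.

From the compounds shown here alone, it stays open whether this holds for alkyl groups generally or for cyclopropylmethyl alone. A benzyl group or a longer chain ending in an amine would help separate the two.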